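Dichlorophenyl in place of phenyl on compound 1

The source may hold more compounds than are shown below. What is called first, only, known or untested is meant among the compounds shown, and "the series" means these compounds.

Measured so far:
compound 1 `N=C(NCCCc1c[nH]cn1)NCCC(c1ccccc1)c1ccccn1`, 1
compound 2 `c1ccc(C(CCC/N=C(/NCCCc2c[nH]cn2)NC2CCCCC2)c2ccccn2)cc1`, 0.25
compound 3 `Cc1ccc(CC(CC/N=C(/NCCCc2c[nH]cn2)NC2CCCCC2)c2ccccn2)cc1`, 1

In an assay on cardiac atrium with histamine H2 receptor (Cavia porcellus) as the target (on this read-out lower numbers stand for smaller maximal responses and higher numbers for larger maximal responses), compound 1 gives 1, level with compound 3 at the digits shown, within the scatter; together the two are the highest of the three numbers. Compound 2 sits a number lower, beyond the scatter, and is the only one of the three that does not reach the reference response.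

Compound 4 `N=C(NCCCc1c[nH]cn1)NCCC(c1ccc(Cl)c(Cl)c1)c1ccccn1` is the next candidate. It differs from compound 1 by 3,4-dichlorophenyl in place of phenyl on a saturated chain carbon bound to an aromatic carbon and a saturated chain carbon. For the measured compounds named here, no pair of measured compounds shares this change, so there is no measured step to lean on; the only guide is that compound 1 itself reaches 1 in this assay.

Compound 4 is expected to stay near the full response, with a step of a number 0.10 lower from compound 1 to compound 4 (within the scatter), no change beyond the scatter or at most a small drop. Compound 4 is therefore estimated at 0.9, in the range 0.65 to 1.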

Compound 4, intrinsic activity: the largest response reached, as a fraction of the reference agonist's: 1
Compound 4: middle estimate off by 0.10, on the low side; low and high end bracket the measured number.
By their numbers in this assay, from the lowest: compound 2; then compounds 1, 3 and 4 (each within the scatter of the next).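

In this assay, 3,4-dichlorophenyl in place of phenyl on a saturated chain carbon bound to an aromatic carbon and a saturated chain carbon gives no change at the digits printed from compound 1 to compound 4 (within the scatter). For the compounds shown here, this is the only measured step at this position, and it shows that the position accepts the larger 3,4-dichlorophenyl group with the maximal response intact. No measurement at hand explains this outcome.

From the compounds shown here alone, whether a single chlorine, a methoxy group or a hydroxyl group on this phenyl ring would hold the response stays open. So does the outcome of the same 3,4-dichlorophenyl change on compound 2.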